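A few compounds are considered here, and "the series" means these few. Any claim that something is new, unique, unknown or untested is made for them only; others in the source may bear on it.

Measured compounds in a functional assay on HCT-116 cells (Homo sapiens) for antiproliferative activity, read by MTT assay, with a stated time of 48 h; a lower number here means a stronger inhibitor, a higher number a weaker inhibitor:

Compound 1 `N#CC1=C(N)Oc2c(c3nc4ccccc4nc3c3ccccc23)C12C(=O)N(Cc1cnnn1-c1ccc(F)cc1)c1ccccc12` — compound 1 gives > 50000 nM, which is a limit of this assay and not a number.
Compound 2 `N#CC1=C(N)Oc2c(c3nc4ccccc4nc3c3ccccc23)C12C(=O)N(Cc1cnnn1-c1ccc(Cl)cc1)c1ccccc12` — compound 2 gives > 50000 nM, again a limit of this assay rather than a number.
Compound 3 `N#CC1=C(N)Oc2c(N)cc3nc4ccccc4nc3c2C12C(=O)N(Cc1cnnn1-c1cccc(Br)c1)c1ccccc12` — compound 3 gives 26100 nM.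

For the measured compounds named here, compound 3 therefore stands as the only compound of the three with a measured number in this assay; the other two values are limits, as the limit of > 50000 nM in this assay, at which 2 of the 3 values shown sit, records. Going by the values given here, the one step between measured compounds that differ in a single place, a step that the two limits leave unreadable from compound 1 to compound 2, runs between two limits and so cannot be read for size.

Compound 4 `Cc1ccc(Cl)cc1-n1nncc1CN1C(=O)C2(C(C#N)=C(N)Oc3c(N)cc4nc5ccccc5nc4c32)c2ccccc21` is not yet measured. It differs from compound 3 by 5-chloro-2-methylphenyl in place of 3-bromophenyl on an aromatic nitrogen. Among the compounds with values here, no measured step touches this part of the shared core: the only step on record concerns a halogen swap on the phenyl ring and is itself unreadable. There is thus no basis for expecting a step in this assay beyond the usual scatter in either direction.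

Compound 4 is accordingly expected to sit close to compound 3, at an estimated 25000 nM, within a range of 8000 nM to 80000 nM, which means an expected step of a 1.0-fold lower number from compound 3 to compound 4 (0.02 log units; within the scatter).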

Compound 4, half-maximal inhibitory concentration: 37200 nM
Compound 4: the middle estimate sits 1.5-fold (0.17 log units) below what was measured; the range from low to high includes it.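

For the compounds shown here, exchanging 3-bromophenyl for 5-chloro-2-methylphenyl on the aromatic nitrogen of the five-membered ring gives the first readable step at this position in this assay: a 1.4-fold higher number from compound 3 to compound 4 (0.15 log units; within the scatter). Going by these compounds alone, the only earlier step, between compound 1 and compound 2, joins two limits of this assay and cannot be read, so this pair is the first to show that the aryl group on this nitrogen can change in more than one respect at once, with a different halogen and an added methyl, without the number moving beyond the scatter. No information given here accounts for the size of this step, and the statement about this position rests on this single pair.

On these data alone, the two alterations within the exchange remain unseparated, so the separate contributions of the methyl and of the chlorine in place of bromine stay unknown, and a plain phenyl or a 3-chlorophenyl on the same nitrogen would be needed to tell them apart. As far as these compounds go, it also remains open whether a group of another kind at this position, such as a benzyl, or a phenyl carrying an amine or a carboxylic acid, would move the number beyond the scatter.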